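Trifluoromethyl to methoxy in a growth-inhibition series

This account rests on a few compounds, and the source may have more. Where it says the series, first, only, none or still open, it means among the compounds named here.

Three amides sharing one core have been tested in a functional assay on MDA-MB-231 cells (Homo sapiens) for antiproliferative activity, read by sulforhodamine B assay; a lower number here means a stronger inhibitor of growth, a higher number a weaker inhibitor of growth. Compound 1 `Cc1cc(C)c2sc(NC(=O)c3ccc(C(F)(F)F)cc3)nc2c1` gives 0.45 ug/mL. Compound 3 `COc1ccc(C(=O)Nc2nc3c(OC)cccc3s2)cc1` gives 1.25 ug/mL. For compound 2 `COc1ccc2sc(NC(=O)c3ccc(C(F)(F)F)cc3)nc2c1` the test returned only a limit, > 10 ug/mL, so its potency is not known as a number. On the values shown, compound 2 therefore stands at the weak end, sitting at the limit of > 10 ug/mL in this assay, at which 1 of the 3 values shown sits, while compounds 1 and 3 fall inside the measurable range.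

The next compound, compound 4 `COc1ccc(C(=O)Nc2nc3cc(OC)ccc3s2)cc1`, is compound 2 with a single change: methoxy in place of trifluoromethyl on an aromatic carbon. For the measured compounds named here, no measured pair in this set differs in only one place, so there is no directly comparable step to lean on. Compound 3 carries a methoxy on its benzamide ring, as compound 4 will, but it also differs from compound 4 on the core, so it is only a loose point of reference.

The expectation is a step of moderate size towards stronger growth inhibition, held loosely since compound 2 is known only as a limit. For compound 4 the estimated value is 5 ug/mL, expected to lie between 1.5 ug/mL and 10 ug/mL. The step this estimate implies is an at least 2.0-fold lower number from compound 2 to compound 4 (0.30 log units; that floor lies within the scatter).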

Compound 4, concentration for 50% growth inhibition: > 10 ug/mL
Compound 4: a limit, no number (the forecaster's own chance of this, stated with the estimate: 40%); middle value at least 2.0-fold (0.30 log units) from the limit.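

In this assay compound 4 gives > 10 ug/mL, which is a limit and not a number. Compound 2 also gives only a limit, so no step can be read between compound 2 and compound 4: the limit of > 10 ug/mL in this assay, at which 2 of the 4 values shown sit.

The compounds shown leave open whether methoxy in place of trifluoromethyl on an aromatic carbon strengthens, weakens or leaves unchanged the growth inhibition of compound 2.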